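A few compounds are considered here, and "the series" means these few. Any claim that something is new, unique, unknown or untested is made for them only; others in the source may bear on it.

Measured compounds:
- compound 1, `O=S(=O)(c1cccc(F)c1)c1ccc2c(c1)CCC[C@H]2CNCCO`, 0.126 nM in an assay on isolated protein for displacement of a labelled ligand from 5-hydroxytryptamine receptor 6 (Homo sapiens); a lower number here means a stronger inhibitor, a higher number a weaker inhibitor
- compound 2, `N=C(N)NC(=O)C[C@@H]1CCCc2cc(S(=O)(=O)c3cccc(F)c3)ccc21`, 0.631 nM in this assay

Compound 2 gives the highest of the two numbers; its nearest neighbour is compound 1, and the step of a 5.0-fold higher number from compound 1 to compound 2 (0.70 log units; beyond the scatter) lies beyond the scatter. Compound 3, `CNC(=O)NC[C@@H]1CCCc2cc(S(=O)(=O)c3cccc(F)c3)ccc21`, is not yet measured in this assay. It differs from compound 2 by a group of 5 heavy atoms (2 carbon, 2 nitrogen, 1 oxygen; no ring) in place of a group of 6 heavy atoms (2 carbon, 3 nitrogen, 1 oxygen; no ring), on a saturated chain carbon bound to a saturated ring carbon. Among the measured compounds shown here, the only measured step that touches this position is a 5.0-fold higher number from compound 1 to compound 2 (0.70 log units; beyond the scatter), a change of the whole side chain, so it gives limited guidance. Compound 3 is therefore expected to stay near compound 2, with a step of a 1.3-fold lower number from compound 2 to compound 3 (0.10 log units; within the scatter), estimated at 0.5 nM within 0.15 nM to 2 nM.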

Compound 3, inhibition constant: 0.398 nM
The estimate for compound 3 lay 1.3-fold (0.10 log units) above the measured number, within the range that was stated.
By their numbers in this assay, from the lowest: compound 1; then compounds 3 and 2 (each within the scatter of the next).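

In this assay, the saturated chain carbon bound to a saturated ring carbon accepts (methylcarbamoyl)amino in place of the group of compound 2 without a readable change (a 1.6-fold lower number from compound 2 to compound 3 (0.20 log units; within the scatter)). On the amine nitrogen, however, methylcarbamoyl in place of 2-hydroxyethyl gives a modest step beyond the scatter (a 3.2-fold higher number from compound 1 to compound 3 (0.50 log units; beyond the scatter)), so the 2-hydroxyethyl amine remains ahead of both other side chains. No evidence at hand accounts for these differences. Going by these compounds, it remains open how a primary amine, a carboxylic acid or a longer chain would read at this position.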